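Benzoyl to naphthoyl on a benzamide-linked hydroxamic-free scaffold

A few compounds are considered here, and "the series" means these few. Any claim that something is new, unique, unknown or untested is made for them only; others in the source may bear on it.

The measured compounds and their values:
compound 1, `Nc1ccccc1NC(=O)CCCCCN(CC(=O)NC1CCCCC1)C(=O)c1ccccc1`, 30900 nM;
compound 2, `Cc1cc(C)cc(C(=O)N(CC(=O)NCc2ccccc2)Cc2ccc(C(=O)Nc3cc(-c4ccccc4)ccc3N)cc2)c1`, 8900 nM;
compound 3, `CN(C)c1ccc(C(=O)N(CCCCCC(=O)Nc2cc(F)ccc2N)CC(=O)NCc2ccccc2)cc1`, 20200 nM.

All three were read in a functional assay on CAL-27 cells (Homo sapiens) for cytotoxicity, read by MTT assay, with a stated time of 72 h; a higher number here means a weaker inhibitor, a lower number a stronger inhibitor. Compound 1 sits at the high end of the three numbers. Its number and that of compound 3 cannot be told apart within the usual scatter, while compound 2 lies beyond the scatter on the lower, more potent side. None of these three pairs differs in one place only, so no single structural step can be read from them.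

Compound 4, `Nc1ccccc1NC(=O)CCCCCN(CC(=O)NC1CCCCC1)C(=O)c1cccc2ccccc12`, is the untested partner of compound 1. The change is naphthalen-1-yl in place of phenyl on a carbonyl carbon: naphthalen-1-yl in place of phenyl on the carbonyl carbon. Among the measured compounds shown here, no measured pair shows this kind of exchange, and the surrounding numbers give no direction for it. The account therefore expects a step from compound 1 to compound 4 that is small, most likely within the scatter and, if anything, toward a lower number: a 1.5-fold lower number from compound 1 to compound 4 (0.19 log units; within the scatter). The estimate for compound 4 in this assay is 20000 nM, with a range from 7000 nM to 60000 nM.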

Compound 4, half-maximal inhibitory concentration: 24900 nM
Compound 4: the middle estimate sits 1.2-fold (0.10 log units) below what was measured; low and high end bracket the measured number.
By their numbers in this assay, from the lowest: compound 2; then compounds 3, 4 and 1 (each within the scatter of the next).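

In this assay, among the compounds shown here, the exchange of phenyl for naphthalen-1-yl on a carbonyl carbon gives a 1.2-fold lower number from compound 1 to compound 4 (0.09 log units; within the scatter) and is the first change in this set that can be read in a single place. At this position, whose other neighbour on the carbonyl carbon is an amide-type nitrogen, going from one six-membered aromatic ring of carbon only to two, with 10 heavy atoms in place of 6, leaves the cytotoxicity read-out indistinguishable on the core of compound 1. No supporting measurement explains this outcome or bears on it further.

The compounds shown leave open whether this position would tell apart groups of another kind, such as a naphthalen-2-yl ring, a pyridine ring, or a phenyl ring carrying an amine or a carboxylic acid. For the compounds shown here, they also leave open whether the same exchange would give a similar result on the cores of compound 2 and compound 3, which differ from compound 1 in more than one place and offer no further step to read.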